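From ethyl to benzyl: compound 3 and compound 4

A few compounds are considered here, and "the series" means these few. Any claim that something is new, unique, unknown or untested is made for them only; others in the source may bear on it.

Measured in a functional assay on HCT-116 cells (Homo sapiens) for cytotoxicity, read by MTT assay, with a stated time of 48 h; on this read-out higher numbers stand for weaker inhibition of growth and lower numbers for stronger inhibition of growth:

compound 1 `CC(C)c1nc2cc(Cl)c(Cl)cc2[nH]1` gives 52000 nM
compound 2 `OC[C@H]1O[C@@H](n2cnc3cc(F)c(F)cc32)[C@H](O)[C@@H]1O` gives 67000 nM
compound 3 `CCn1c(C(F)(F)F)nc2cc(Cl)c(Cl)cc21` gives 95300 nM

These three numbers sit close together. Compound 1 and compound 2 both lie within the scatter of compound 3, which stands at 95300 nM. Going by the values given here, no measured compound here stands apart from the others.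

Compound 4 `FC(F)(F)c1nc2cc(Cl)c(Cl)cc2n1Cc1ccccc1` has not yet been measured. It differs from compound 3 in one place: phenyl in place of methyl on a saturated chain carbon bound to an aromatic nitrogen. This puts phenyl in place of methyl on a saturated chain carbon bound to an aromatic nitrogen, so that ethyl becomes benzyl.

Among the compounds with values here, no measured pair shows what a single change of this kind does. In this assay the expectation is therefore no step beyond the scatter, with a slight lean toward stronger inhibition of growth. It rests on compound 3 at 95300 nM and on how closely the other two numbers lie to it. The expected step is a 1.4-fold lower number from compound 3 to compound 4 (0.13 log units; within the scatter). Compound 4 is estimated at 70000 nM, with an expected range of 25000 nM to 130000 nM.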

Compound 4, concentration for 50% growth inhibition: 8600 nM
Compound 4: the middle estimate sits 8.1-fold (0.91 log units) above what was measured; measured number below the stated range.
By their numbers in this assay, from the lowest: compound 4; then compounds 1, 2 and 3 (each within the scatter of the next).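

In this assay, phenyl in place of methyl on a saturated chain carbon bound to an aromatic nitrogen gives an 11-fold lower number from compound 3 to compound 4 (1.04 log units; beyond the scatter), a large step beyond the scatter. Going by these compounds alone, it shows that growth inhibition responds to what this place carries, which the earlier compounds could not show, since none of them formed a pair differing in one place. No measurement at hand bears on the reason for this step.

From the compounds shown here alone, it remains open whether the phenyl ring itself is needed or whether a longer chain such as propyl, or a cyclohexyl ring, would give a similar step. This single pair also leaves open whether a phenyl ring carrying a methoxy group or an amine would keep the step, and whether the same change would act alike on another core.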